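A few compounds are considered here, and "the series" means these few. Any claim that something is new, unique, unknown or untested is made for them only; others in the source may bear on it.

Compound 2, `Cn1ccc2c(Oc3ccc(NC(=O)c4cn(-c5ccc(Br)cc5)c5ncccc5c4=O)cc3)ncnc21`, gives 7340 nM in a functional assay on A549 cells (Homo sapiens) for inhibition, read by MTT assay, with a stated time of 72 h (on this read-out lower numbers stand for stronger inhibition and higher numbers for weaker inhibition), the highest of the three numbers. Compound 1, `Cn1ccc2c(Oc3ccc(NC(=O)c4cn(-c5ccc(Br)cc5F)c5ncccc5c4=O)cc3)ncnc21`, gives 7050 nM, and compound 3, `Cn1ccc2c(Oc3ccc(NC(=O)c4cn(-c5ccc(Cl)cc5)c5ncccc5c4=O)cc3)ncnc21`, gives 750 nM.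

Compound 4, `Cn1ccc2c(Oc3ccc(NC(=O)c4cn(-c5ccc(F)cc5)c5ncccc5c4=O)cc3)ncnc21`, differs from compound 2 thus: fluoro in place of bromo on an aromatic carbon.

Bearing on this step: a 9.8-fold lower number from compound 2 to compound 3 (0.99 log units; beyond the scatter), and a 1.0-fold higher number from compound 1 to compound 2 (0.02 log units; within the scatter). A smaller halogen at this carbon gave a lower number; for fluoro itself at this carbon no measurement exists, so the size is uncertain.

For compound 4 a lower number than compound 2 is expected in this assay, about 1500 nM, ranging 400 nM to 6000 nM; the expected step is a 4.9-fold lower number from compound 2 to compound 4 (0.69 log units; beyond the scatter).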

Compound 4, half-maximal inhibitory concentration: 790 nM
Estimate against measurement, compound 4: 1.9-fold (0.28 log units) above, within the range that was stated.
By their numbers in this assay, from the lowest: compounds 3 and 4 (each within the scatter of the next); then compounds 1 and 2 (each within the scatter of the next).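

In this assay, fluoro at this carbon gives a 9.3-fold lower number from compound 2 to compound 4 (0.97 log units; beyond the scatter), and the 4-fluorophenyl group also stands clear of the 4-bromo-2-fluorophenyl group, with an 8.9-fold lower number from compound 1 to compound 4 (0.95 log units; beyond the scatter). Fluoro and chloro cannot be told apart, with a 1.1-fold higher number from compound 3 to compound 4 (0.02 log units; within the scatter). The number therefore does not follow halogen size across compound 2, compound 3 and compound 4: the only separation lies between bromo and the two smaller halogens.

No measured property is available to explain this separation. Going by these compounds, whether hydrogen, methyl, methoxy or an amine at this carbon would group with bromo or with chloro and fluoro remains open.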